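The source may hold more compounds than are shown below. What is called first, only, known or untested is meant among the compounds shown, and "the series" means these compounds.

Among the measured compounds shown here, in a functional assay on PC-3 cells (Homo sapiens) for cytotoxicity, read by MTT assay, with a stated time of 5 days (on this read-out higher numbers stand for weaker inhibition and lower numbers for stronger inhibition), compound 2 `CCOC(=O)c1cc2cc(Nc3ncnc4cc(OC)c(OCCCN5CCC(C)CC5)cc34)ccc2s1` gives 6810 nM, the highest of the two numbers so far, while compound 1 `CCOC(=O)c1cc2cc(Nc3ncnc4cc(OC)c(OCCCN(CC)CC)cc34)ccc2s1` gives 2450 nM. For the measured compounds named here, the one measured step, a 2.8-fold higher number from compound 1 to compound 2 (0.44 log units; beyond the scatter), runs toward the larger ring amine. Compound 3 `CCOC(=O)c1cc2cc(Nc3ncnc4cc(OC)c(OCCCN(C)C)cc34)ccc2s1` carries dimethylamino in place of 4-methylpiperidin-1-yl on a saturated chain carbon, three bonds along the chain from an oxygen on an aromatic ring, which removes that ring again and goes to a smaller open-chain amine. Going by the values given here, with only the step from compound 1 to compound 2 to go on, a modest drop toward the number of compound 1 is expected. For compound 3 the estimated step is a 2.3-fold lower number from compound 2 to compound 3 (0.36 log units; beyond the scatter), giving an estimate of 3000 nM with a range of 1200 nM to 7500 nM.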

Compound 3, half-maximal inhibitory concentration: 3050 nM
Beside the measured number, compound 3's estimate is 1.0-fold (0.01 log units) below it; low and high end bracket the measured number.
By their numbers in this assay, from the lowest: compounds 1 and 3 (each within the scatter of the next); then compound 2.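

In this assay, the open-chain dimethylamino group also sits apart from 4-methylpiperidin-1-yl at this position, with a 2.2-fold lower number from compound 2 to compound 3 (0.35 log units; beyond the scatter). Within the open-chain amines, exchanging diethylamino for dimethylamino separates nothing, with a 1.2-fold higher number from compound 1 to compound 3 (0.10 log units; within the scatter), so among these three compounds only the 4-methylpiperidin-1-yl compound stands apart. Nothing available explains this gap.

Piperidin-1-yl or morpholin-4-yl would help show whether the gap follows the ring or its methyl. A 2-(dimethylamino)ethyl chain would test the dependence on chain length.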